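Fluoro for Trifluoromethyl: Cytotoxicity of Three Measured Analogues

The source may report more compounds than this note shows. Statements on the series, on what has been measured and on what is new or still open speak of the compounds shown alone.

Compound 1 `CCc1ccc(-c2nc3c(c(C)nn3-c3ccccc3)c(-c3ccccc3F)c2C#N)cc1`: in an ADME assay on BJ cells (Homo sapiens) for cytotoxicity, with a stated time of 72 h (a lower number here means that less compound is needed, a higher number that more compound is needed for the effect), compound 1 gives > 20000 nM, a limit of the assay and not a number.
Compound 2 `CCc1ccc(-c2nc3c(c(C)nn3-c3ccccc3)c(-c3ccccc3C(F)(F)F)c2C#N)cc1`: in this assay compound 2 gives > 20000 nM, again a limit.
Compound 3 `Cc1nn(-c2ccccc2)c2nc(-c3ccc(C(F)(F)F)cc3)c(C#N)c(-c3ccccc3O)c12`: in this assay compound 3 gives 22900 nM.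

Among the measured compounds shown here, compound 3 carries the only number in the set; the other two values sit at the limit of > 20000 nM in this assay, at which 2 of the 3 values shown sit. The change from compound 2 to compound 1, (fluoro in place of trifluoromethyl on an aromatic carbon), gives a step that the two limits leave unreadable from compound 2 to compound 1. Compound 4 `Cc1nn(-c2ccccc2)c2nc(-c3ccc(F)cc3)c(C#N)c(-c3ccccc3O)c12` is not yet measured; it differs from compound 3 by fluoro in place of trifluoromethyl on an aromatic carbon. This is the same kind of change as that between compound 2 and compound 1, though the surroundings differ: in compound 2 the group sits ortho to a large group, in compound 3 para to a large group. The difference between the cores of compound 3 and compound 2 is not broken down here.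

Compound 4 is expected to stay weakly cytotoxic, since compound 3 gives 22900 nM and the parallel step that the two limits leave unreadable from compound 2 to compound 1 offers no readable size. The step this expectation means is a 1.1-fold higher number from compound 3 to compound 4 (0.04 log units; within the scatter). Compound 4 is estimated at 25000 nM, between 12000 nM and 60000 nM, with a fair chance that only a limit is reported.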

Compound 4, half-maximal effective concentration in the BJ assay: > 20000 nM
Compound 4: a limit, no number (the forecaster's own chance of this, stated with the estimate: 55%); the middle value lies beyond the limit too.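

In the BJ assay compound 4 gives > 20000 nM, a limit and not a number. Among the compounds shown here, no step from compound 3 to compound 4 can be read in this assay. The compounds shown leave open how far fluoro in place of trifluoromethyl shifts this read-out, as neither pair with that change has two numbers. In a physicochemical assay for solubility, read by spectrophotometry, in phosphate buffer, with a stated time of 18 h, at pH 7.4 (on this read-out lower numbers stand for lower solubility and higher numbers for higher solubility), compound 3 gives 3500 nM and compound 4 gives 6000 nM, with a 1.7-fold higher number from compound 3 to compound 4 (0.23 log units; within the scatter).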